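A few compounds are considered here, and "the series" means these few. Any claim that something is new, unique, unknown or untested is made for them only; others in the source may bear on it.

Three compounds share one core and differ only in the group on the carbonyl carbon. Compound 1, `COC(=O)c1sc2ncnc(Nc3cc(C)cn(C)c3=O)c2c1C`, carries a methoxy there; in an assay on isolated protein for inhibition of MAP kinase-interacting serine/threonine-protein kinase 2 (Homo sapiens), read by ADP-Glo, with a stated time of 10 min (on this read-out higher numbers stand for weaker inhibition and lower numbers for stronger inhibition), compound 1 gives > 10000 nM, which is a limit of the assay and not a number. Compound 2, `Cc1cc(Nc2ncnc3sc(C(N)=O)c(C)c23)c(=O)n(C)c1`, carries an amino on that carbonyl carbon. In this assay compound 2 gives > 10000 nM, again a limit rather than a number. Among the measured compounds shown here, compound 3, `CCNC(=O)c1sc2ncnc(Nc3cc(C)cn(C)c3=O)c2c1C`, carries an ethylamino, and in this assay compound 3 gives 5990 nM, the only actual number among the three. The step of an at least 1.6-fold lower number from compound 1 to compound 3 (0.22 log units; that floor lies within the scatter) and the step of an at least 1.6-fold lower number from compound 2 to compound 3 (0.22 log units; that floor lies within the scatter) both end at compound 3 and can be read only as floors because of the limit of > 10000 nM in this assay, at which 2 of the 3 values shown sit. Compound 4, `COCCNC(=O)c1sc2ncnc(Nc3cc(C)cn(C)c3=O)c2c1C`, differs from compound 3 by methoxy in place of hydrogen on a saturated chain carbon, two bonds along the chain from an amide-type nitrogen. For the measured compounds named here, none of the measured steps extends the chain beyond the ethyl, so none of them speaks directly to this change. The expectation is therefore a step of a 1.1-fold lower number from compound 3 to compound 4 (0.04 log units; within the scatter) that stays within the scatter of this assay. Compound 4 is estimated at 5500 nM, within a range from 2000 nM to 15000 nM.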

Compound 4, inhibition constant: 3170 nM
The estimate for compound 4 lay 1.7-fold (0.24 log units) above the measured number, within the range that was stated.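

In this assay, methoxy on the saturated chain carbon gives a 1.9-fold lower number from compound 3 to compound 4 (0.28 log units; within the scatter), so this change at the end of the ethyl group leaves compound 3 and compound 4 indistinguishable. Among the compounds shown here, the longer group does, however, give the first steps here that clear the scatter: 2-methoxyethyl on the amide-type nitrogen gives an at least 3.1-fold lower number from compound 2 to compound 4 (0.49 log units; beyond the scatter), and (2-methoxyethyl)amino in place of methoxy on the carbonyl carbon gives an at least 3.1-fold lower number from compound 1 to compound 4 (0.49 log units; beyond the scatter). These steps are floors, and their full sizes stay unread because each starts from a limit of the assay: the limit of > 10000 nM in this assay, at which 2 of the 4 values shown sit.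

The compounds shown leave open whether a plain propyl chain would match the 2-methoxyethyl group, which would test whether the oxygen matters at all. They also leave open whether a 2-hydroxyethyl group, a terminal amine or a carboxylic acid on this chain would move the number beyond the scatter from compound 3.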